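Amide replacement of the benzylamine arm in a CXCR4 series

A few compounds are considered here, and "the series" means these few. Any claim that something is new, unique, unknown or untested is made for them only; others in the source may bear on it.

Measured so far:
compound 1, `NCc1ccccc1CN(Cc1nc2ccccc2[nH]1)C1CCCc2cccnc21`, 50 nM
compound 2, `NCCN(Cc1nc2ccccc2[nH]1)C1CCCc2cccnc21`, 1370 nM
compound 3, `CNCCCCN(Cc1nc2ccccc2[nH]1)C1CCCc2cccnc21`, 190 nM

In a functional assay on CEM-CCRF cells for antagonist activity at C-X-C chemokine receptor type 4 (Homo sapiens), read by calcium flux (a lower number here means a stronger inhibitor, a higher number a weaker inhibitor), compound 1 gives the lowest number of the three. Compound 4, `NCCCC(=O)N(Cc1nc2ccccc2[nH]1)C1CCCc2cccnc21`, differs from it as follows: (3-aminopropyl)carbonyl in place of 2-(aminomethyl)benzyl on an amine nitrogen. Two measured steps speak to this kind of change. Replacing the aryl arm with a short chain gave a 27-fold higher number from compound 1 to compound 2 (1.44 log units; beyond the scatter), and replacing it with a longer chain carrying an amine gave a 3.8-fold higher number from compound 1 to compound 3 (0.58 log units; beyond the scatter). Both chain replacements raised the number, the longer chain less so. For the measured compounds named here, the entering group in compound 4 matches the longer chain in length but joins through a carbonyl, for which no measured step exists. A rise beyond the scatter is therefore expected, in the range between those two steps: for compound 4 the estimate is 600 nM (150 nM to 3000 nM), meaning an expected step of a 12-fold higher number from compound 1 to compound 4 (1.08 log units; beyond the scatter).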

Compound 4, half-maximal inhibitory concentration: 3200 nM
Compound 4: middle estimate off by 5.3-fold (0.73 log units), on the low side, and the stated range ends below it.
By their numbers in this assay, from the lowest: compound 1; then compound 3; then compound 2; then compound 4.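

In this assay the (3-aminopropyl)carbonyl arm is the weakest of the four, with a 64-fold higher number from compound 1 to compound 4 (1.81 log units; beyond the scatter) and a 17-fold higher number from compound 3 to compound 4 (1.23 log units; beyond the scatter) as its two large steps. Even the short 2-aminoethyl arm does better, as a 2.3-fold higher number from compound 2 to compound 4 (0.37 log units; beyond the scatter) shows, so on this amine nitrogen the chain joined through a carbonyl falls behind both chains without one. Nothing measured here explains this loss. Still open, from the compounds shown here alone, is whether the carbonyl would cost as much with the aromatic ring kept, as in a 2-(aminomethyl)benzoyl arm. A 3-aminobutyl or 4-aminobutyl arm, with no carbonyl and no methyl on its amine, would also give a closer comparison.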